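The compounds below may be only part of what the source reports. "The series", "measured", "known", "first", "only" and "open" are said of these compounds alone.

Working notes on the series.

Compound 1 `COc1ncc(-c2ccc3c(c2)NC(=O)CO3)cc1NS(=O)(=O)c1ccc(F)cc1` in a functional assay on HeLa cells (Homo sapiens) for antiproliferative activity, read by MTT assay, with a stated time of 72 h (on this read-out lower numbers stand for stronger inhibition and higher numbers for weaker inhibition), gives 7110 nM. Compound 3 `COc1ncc(-c2ccc3c(c2)N(c2ccc(Cl)cc2)C(=O)CO3)cc1NS(=O)(=O)c1ccc(F)cc1` gives 4830 nM. The change between them is 4-chlorophenyl in place of hydrogen on an amide-type nitrogen in a ring and the step is a 1.5-fold lower number from compound 1 to compound 3 (0.17 log units; within the scatter).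

Compound 2 `O=C1COc2ccc(-c3cnc4ccccc4c3)cc2N1` gives only a limit of the assay, > 40000 nM, as noted in the limit of > 40000 nM in this assay, at which 1 of the 3 values shown sits. How the core of compound 2 differs from the core of compound 1 is not broken down here.

Compound 4 `O=C1COc2ccc(-c3cnc4ccccc4c3)cc2N1c1ccc(Cl)cc1` is not yet measured. It carries the same change as compound 3, namely (4-chlorophenyl in place of hydrogen on an amide-type nitrogen in a ring), and the place is the same in both pairs. Given that the measured step of a 1.5-fold lower number from compound 1 to compound 3 (0.17 log units; within the scatter) lies within the scatter, the expected step is an at least 1.1-fold lower number from compound 2 to compound 4 (0.05 log units; that floor lies within the scatter), and the starting point of compound 2 is itself a limit, > 40000 nM. Compound 4 is therefore estimated at 35000 nM, with a likely range from 15000 nM to 80000 nM.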

Compound 4, half-maximal inhibitory concentration: > 40000 nM
Compound 4: no number, only a limit; the forecaster's own chance of this, stated with the estimate: 55%; middle value at least 1.1-fold (0.05 log units) away from the limit.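

Compound 2 and compound 4 both stand only at a limit in this assay, so no step can be read between them: the limit of > 40000 nM in this assay, at which 2 of the 4 values shown sit.

The compounds shown leave open what 4-chlorophenyl in place of hydrogen does on the core of compound 2.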